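From benzyloxycarbonyl to acetyl on a shared core

The compounds below may be only part of what the source reports. "The series", "measured", "known", "first", "only" and "open" are said of these compounds alone.

Compound 1 `O=C(O)CCn1c2ccc([N+](=O)[O-])cc2c(=O)n1Cc1ccccc1` and compound 2 `O=C(OCc1ccccc1)n1c2ccc([N+](=O)[O-])cc2c(=O)n1Cc1ccccc1` share a core and differ on an aromatic nitrogen. In an ADME assay on L929 cells (Mus musculus) for cytotoxicity, read by resazurin assay, with a stated time of 48 h (a lower number here means that less compound is tolerated, a higher number that more compound is tolerated), compound 1 returns > 256000 nM as a limit and not a number. In this assay, for the measured compounds named here, compound 2 gives 86100 nM as the only actual number so far. The step to compound 3 `CC(=O)n1c2ccc([N+](=O)[O-])cc2c(=O)n1Cc1ccccc1` is methyl in place of benzyloxy on a carbonyl carbon and reads, in words, methyl in place of benzyloxy on a carbonyl carbon. Going by the values given here, one measured step bears on this: an at least 2.9-fold lower number from compound 1 to compound 2 (0.47 log units; beyond the scatter) came with benzyloxycarbonyl in place of 2-carboxyethyl, and it is modest but beyond the scatter. Part of that group now leaves, so a modest move to a higher number is expected in this assay from this one precedent. The expected step is a 2.1-fold higher number from compound 2 to compound 3 (0.32 log units; beyond the scatter) in size. Compound 3 is estimated at 180000 nM with a range from 70000 nM to 350000 nM as its expected span.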

Compound 3, concentration lethal to 50% of the cells: > 256000 nM
Compound 3: a limit, no number; the forecaster's own chance of this, stated with the estimate: 30%; at least 1.4-fold (0.15 log units) between middle value and limit.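

Replacing benzyloxy with methyl on a carbonyl carbon removes the six-membered aromatic ring of the benzyloxycarbonyl group, and in this assay this gives an at least 2.9-fold higher number from compound 2 to compound 3 (0.47 log units; beyond the scatter). Compound 3 gives > 256000 nM, which is a limit and not a number. Among the compounds shown, only benzyloxycarbonyl on the aromatic nitrogen comes with an actual number, while acetyl and 2-carboxyethyl both stop at the limit, so the step between compound 1 and compound 3 cannot be read: the limit of > 256000 nM in this assay, at which 2 of the 3 values shown sit.

The compounds shown leave open how far the true values of compound 1 and compound 3 lie from that limit. They also leave open whether a benzoyl group, which has the aromatic ring without the oxygen, or an ethoxycarbonyl group, which has the oxygen without the ring, would give a number or stay at the limit.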